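This account rests on a few compounds, and the source may have more. Where it says the series, first, only, none or still open, it means among the compounds named here.

In an ADME assay on HepG2 cells (Homo sapiens) for cytotoxicity, read by MTT assay, with a stated time of 72 h (a higher number here means that more compound is tolerated, a lower number that less compound is tolerated), compound 3 `O=[N+]([O-])c1c(CS(=O)(=O)c2ccccc2)nc2c(C#Cc3cccnc3)cc(Cl)cn12` gives > 3900 nM as a limit, not a number. Compound 1 `COc1ccc(C#Cc2cc(Cl)cn3c([N+](=O)[O-])c(CS(=O)(=O)c4ccccc4)nc23)cc1` gives > 3900 nM as a limit as well. Compound 2 `COc1ccccc1C#Cc1cc(Cl)cn2c([N+](=O)[O-])c(CS(=O)(=O)c3ccccc3)nc12` gives > 3900 nM as a limit too. Compound 3 therefore has no position of its own within the set, and the evidence so far is the limit of > 3900 nM in this assay, at which 3 of the 3 values shown sit, and nothing finer.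

The move to compound 4 `CC(C)(O)C#Cc1cc(Cl)cn2c([N+](=O)[O-])c(CS(=O)(=O)c3ccccc3)nc12` is 1-hydroxy-1-methylethyl in place of pyridin-3-yl on a triple-bonded carbon and it sits on a triple-bonded carbon, turning 2-(pyridin-3-yl)ethynyl into 3-hydroxy-3-methylbut-1-yn-1-yl. The measured steps at this same place are a step that the two limits leave unreadable from compound 1 to compound 2 with 2-methoxyphenyl for 4-methoxyphenyl, a step that the two limits leave unreadable from compound 1 to compound 3 with pyridin-3-yl for 4-methoxyphenyl, and a step that the two limits leave unreadable from compound 2 to compound 3 with pyridin-3-yl for 2-methoxyphenyl. None of them has a readable size, and none brings in 1-hydroxy-1-methylethyl, so they bear on the change only weakly.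

The expected step is a step that the limit leaves unreadable from compound 3 to compound 4. The measured steps give it neither size nor direction. In this assay a further limit is the likeliest expected outcome. For compound 4 the estimate is 6000 nM within an expected range of 3000 nM to 25000 nM for the half-maximal cytotoxic concentration.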

Compound 4, half-maximal cytotoxic concentration: > 62500 nM
Compound 4: a limit, no number; the forecaster's own chance of this, stated with the estimate: 80%; at least 10-fold (1.01 log units) between middle value and limit.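

In this assay compound 4 gives > 62500 nM, a limit and not a number. With compound 1, compound 2 and compound 3 also standing as limits, none of their steps to compound 4 can be read. The compounds shown leave open whether 1-hydroxy-1-methylethyl differs at all from pyridin-3-yl, 2-methoxyphenyl or 4-methoxyphenyl in the half-maximal cytotoxic concentration.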